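The source may hold more compounds than are shown below. What is called first, only, known or untested is meant among the compounds shown, and "the series" means these compounds.

The series shares one core, seen in compound 1 `NC(=O)c1cccc(CN(CCCC(=O)O)C[C@H]2O[C@@H](n3cnc4c(N)ncnc43)[C@H](O)[C@@H]2O)c1`, compound 2 `Nc1ncnc2c1ncn2[C@@H]1O[C@H](CN(CCCC(=O)O)Cc2cccc(C(=O)O)c2)[C@@H](O)[C@H]1O` and compound 3 `Nc1ncnc2c1ncn2[C@@H]1O[C@H](CN(CCCC(=O)O)Cc2ccc3ccccc3c2)[C@@H](O)[C@H]1O`. In an assay on cells for inhibition of Nicotinamide N-methyltransferase (Homo sapiens), with stated times of 10 min and 30 min (a lower number here means a stronger inhibitor, a higher number a weaker inhibitor), compound 1 returns no number, only the limit of the assay, > 250000 nM. Compound 2 likewise gives only a limit, > 250000 nM. Compound 3 too gives no number but a limit, > 250000 nM. Because all three sit at the limit of > 250000 nM in this assay, at which 3 of the 3 values shown sit, none of the steps among them can be sized: the step that the two limits leave unreadable from compound 1 to compound 2, the step that the two limits leave unreadable from compound 1 to compound 3 and the step that the two limits leave unreadable from compound 2 to compound 3 all remain unreadable. Compound 3 therefore stands nowhere that can be placed against the other two; it is known only to be at the limit.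

Compound 4 `Nc1ncnc2c1ncn2[C@@H]1O[C@H](CN(CCC[C@H](N)C(=O)O)Cc2ccc3ccccc3c2)[C@@H](O)[C@H]1O` differs from compound 3 by amino(carboxy)methyl in place of carboxy on a saturated chain carbon, three bonds along the chain from an amine nitrogen. No measured step among these compounds touches such an addition, and the three unreadable steps offer no size to carry over. What they do show is that every compound here has stayed at the limit, so the expected step from compound 3 to compound 4 in this assay is a step that the limit leaves unreadable from compound 3 to compound 4, that is, nothing readable. Compound 4 is accordingly estimated at 300000 nM, with a range from 50000 nM to 2000000 nM, and most probably it will again return only a limit.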

Compound 4, half-maximal inhibitory concentration: > 250000 nM
Compound 4 gave a limit, no number (the forecaster's own chance of this, stated with the estimate: 85%); the middle value does not contradict the limit.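

Compound 4, like compound 3, returns only a limit and no number, so no size can be read for the change from compound 3 to compound 4, and all the compounds share one limit: the limit of > 250000 nM in this assay, at which 4 of the 4 values shown sit.

The compounds shown leave open how strongly any of the four inhibits in this assay, and which change to the shared core, if any, would yield a readable number.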